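The source may report more compounds than this note shows. Statements on the series, on what has been measured and on what is new or still open speak of the compounds shown alone.

Of the compounds shown here, two built on the same shared core have been measured in an assay for inhibition of 6-phosphofructo-2-kinase/fructose-2,6-bisphosphatase 3 (Homo sapiens), read by ADP-Glo, with a stated time of 2 h; on this read-out lower numbers stand for stronger inhibition and higher numbers for weaker inhibition. Compound 1 `CN1CCCC(NS(=O)(=O)c2ccccc2Nc2cc(-c3ccc4ccn(C)c4c3)c3nccnc3c2)C1` gives 59 nM in this assay. Compound 2 `Cn1cc(NC(=O)c2ccncc2Nc2cc(-c3ccc4ccn(C)c4c3)c3nccnc3c2)cn1` gives 33 nM in this assay. Of these two numbers, compound 2 shows the smaller one, but compound 1 sits so close that the gap between them lies within the usual scatter of repeated measurements, so no real difference in potency can be claimed.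

Compound 3 `CC(=O)N1CCC(NC(=O)c2ccncc2Nc2cc(-c3ccc4ccn(C)c4c3)c3nccnc3c2)C1` has not yet been measured. It differs from compound 2 in a single place: 1-acetylpyrrolidin-3-yl in place of 1-methyl-1H-pyrazol-4-yl on an amide-type nitrogen. For the measured compounds named here, no measured pair shows what such an exchange does on this core, so the direction of the step is open. The expected step is a 1.4-fold higher number from compound 2 to compound 3 (0.13 log units; within the scatter), a change that would not go beyond the scatter. Compound 3 is therefore expected to give about 45 nM in this assay, with a likely range from 15 nM to 150 nM.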

Compound 3, half-maximal inhibitory concentration: 105 nM
Compound 3: middle estimate off by 2.3-fold (0.37 log units), on the low side; measured number inside the range.
By their numbers in this assay, from the lowest: compounds 2, 1 and 3 (each within the scatter of the next, the first and the last beyond it).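

For the compounds shown here, this is the first readable exchange on the amide-type nitrogen of the shared core: in this assay, putting 1-acetylpyrrolidin-3-yl in place of 1-methyl-1H-pyrazol-4-yl gives a 3.2-fold higher number from compound 2 to compound 3 (0.50 log units; beyond the scatter), a modest step that lies beyond the scatter. The group on this nitrogen therefore does matter for the read-out, yet a non-aromatic ring still leaves compound 3 at 105 nM, so the aromatic ring is not essential for measurable inhibition. Nothing shown here explains the rise.

This single exchange changes the ring type and adds the acetyl group together, so the contribution of each remains unresolved. From the compounds shown here alone, a pyrrolidin-3-yl group with a free amine, or a phenyl ring on the same nitrogen, would help separate the two, and how either would read remains open.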